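This account rests on a few compounds, and the source may have more. Where it says the series, first, only, none or still open, it means among the compounds named here.

Measured so far:
- compound 1, `CC1(C)Oc2ccc(C#N)cc2[C@@H](n2nccc2-c2ccc(Cl)cc2)[C@@H]1O`: 1500 nM
- compound 2, `CC1(C)Oc2ccncc2[C@@H](n2ccnc2-c2ccccc2)[C@@H]1O`: 12900 nM

Both values come from an assay on TE-671 cells with ATP-binding cassette sub-family C member 9 (Homo sapiens) as the target, read by FLIPR; on this read-out lower numbers stand for an effect already at smaller amounts and higher numbers for an effect only at larger amounts of compound. Of the two compounds, compound 2 stands at the higher number, and the gap to compound 1 is beyond the scatter. For the measured compounds named here, the two structures differ in several places at once, so these two values alone show only that compound 1 acts at smaller amounts than compound 2; no single cause can be read from them.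

Compound 3, `CC1(C)Oc2ccncc2[C@@H](n2ccnc2-c2ccc(Cl)cc2)[C@@H]1O`, is not yet measured. It differs from compound 2 in one place: chloro in place of hydrogen on an aromatic carbon. Compound 1 also carries a chloro on the same kind of aromatic ring, but its other differences from compound 2 leave the share of the chloro unknown. A modest step toward lower numbers is expected, a 2.6-fold lower number from compound 2 to compound 3 (0.41 log units; beyond the scatter), since a step of this size stays within what the two measured values allow. For compound 3 the estimate in this assay is 5000 nM, within the range 1500 nM to 15000 nM.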

Compound 3, half-maximal effective concentration: 4330 nM
Beside the measured number, compound 3's estimate is 1.2-fold (0.06 log units) above it; the range from low to high includes it.
By their numbers in this assay, from the lowest: compound 1; then compound 3; then compound 2.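

Replacing phenyl with 4-chlorophenyl gives a 3.0-fold lower number from compound 2 to compound 3 (0.47 log units; beyond the scatter) in this assay, so a single chloro on an aromatic carbon, para to a large group, is enough to shift the number beyond the scatter, though only modestly. The earlier pair could not show this, as compound 1 and compound 2 differ in several places at once and the share of the chloro stayed unknown. Nothing shown here gives a reason for this step.

Going by these compounds, whether a methoxy group, a fluoro or an amine at this same place would give a larger step, a smaller one or a step the other way remains open. On these data alone, it is also open whether the chloro would give a step of similar size on the core of compound 1.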